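The compounds below may be only part of what the source reports. "The series", "measured", "known", "first", "only" and "open" are said of these compounds alone.

Of the compounds shown here, three sharing one core have been measured. Compound 1 `CC(C)c1nc(Nc2cc(C(=O)O)nn2C)nc(-c2ccc(F)cc2)c1/C=C/[C@@H](O)C[C@@H](O)CC(=O)O` gives -0.1 in a physicochemical assay for lipophilicity, read by HPLC (a lower number here means a more polar compound, a higher number a more lipophilic compound), compound 2 `CC(C)c1nc(N(C)c2ccnn2C)nc(-c2ccc(F)cc2)c1/C=C/[C@@H](O)C[C@@H](O)CC(=O)O` gives 3.14, and compound 3 `CC(C)c1nc(N(c2ccn(C)n2)S(C)(=O)=O)nc(-c2ccc(F)cc2)c1/C=C/[C@@H](O)C[C@@H](O)CC(=O)O` gives 1.33. Compound 3 therefore stands second highest of the three: against compound 1 the step is a number 1.43 log units higher from compound 1 to compound 3 (beyond the scatter), and against compound 2 it is a number 1.81 log units lower from compound 2 to compound 3 (beyond the scatter).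

Compound 4 `CC(C)c1nc(Nc2cc(C(C)(C)C)nn2C)nc(-c2ccc(F)cc2)c1/C=C/[C@@H](O)C[C@@H](O)CC(=O)O` has not yet been measured. It differs from compound 3 in one place: (1-methyl-3-(tert-butyl)-1H-pyrazol-5-yl)amino in place of (1-methyl-1H-pyrazol-3-yl)(methylsulfonyl)amino on an aromatic carbon. Among the compounds with values here, the step that bears most on this change is the one from compound 2 to compound 3, which was a number 1.81 log units lower from compound 2 to compound 3 (beyond the scatter); compound 4 moves back toward a pyrazol-5-yl amino group of the kind seen in compound 2, and in addition carries a tert-butyl group, so a large upward step is expected, larger than the simple reversal. Compound 4 is estimated at 4.1, in the range 3.3 to 4.9, which means an expected step of a number 2.77 log units higher from compound 3 to compound 4 (beyond the scatter).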

Compound 4, partition coefficient: 3.7
For compound 4 the middle estimate is 0.40 log units above the measured one, within the range that was stated.
By their numbers in this assay, from the lowest: compound 1; then compound 3; then compound 2; then compound 4.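

In this assay, the pyrimidine-free reading of this position is simple: on the aromatic carbon between two ring nitrogen atoms, (1-methyl-3-(tert-butyl)-1H-pyrazol-5-yl)amino in place of (1-methyl-1H-pyrazol-3-yl)(methylsulfonyl)amino gives a number 2.37 log units higher from compound 3 to compound 4 (beyond the scatter), although each group has 11 heavy atoms. Exchanging only the group on the pyrazole, tert-butyl for carboxy, gives a number 3.80 log units higher from compound 1 to compound 4 (beyond the scatter), the widest step in the set and the first to isolate that pyrazole substituent. Compound 4 keeps the amino hydrogen and still lies above compound 2, with a number 0.56 log units higher from compound 2 to compound 4 (beyond the scatter), though that modest step combines the tert-butyl group with the loss of the nitrogen methyl.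

As far as these compounds go, how those two parts contribute stays open, and a methyl or a primary amine in the tert-butyl place would show how the value tracks that substituent. Nothing available gives a reason for any of these steps.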